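The source may report more compounds than this note shows. Statements on the series, on what has been measured and on what is new or still open speak of the compounds shown alone.

Measured in a functional assay on NCI-H520 cells (Homo sapiens); a lower number here means a stronger inhibitor of growth, a higher number a weaker inhibitor of growth:
- Compound 1 `O=S(=O)(/C=C/c1ccc(Br)cc1)Cc1ccc(Nc2ncnc3ccc(Br)cc23)cc1`: 20000 nM
- Compound 2 `O=S(=O)(/C=C/c1ccc(C(F)(F)F)cc1F)Cc1ccc(Nc2ncnc3ccc(Br)cc23)cc1`: 40000 nM
- Compound 3 `O=S(=O)(/C=C/c1ccc(F)cc1F)Cc1ccc(Nc2ncnc3ccc(Br)cc23)cc1`: 100000 nM

Compound 2 cannot be separated from compound 1 on these numbers, with a 2.0-fold higher number from compound 1 to compound 2 (0.30 log units; within the scatter). Compound 3 lies clearly higher, with a 2.5-fold higher number from compound 2 to compound 3 (0.40 log units; beyond the scatter). Compound 4 `O=S(=O)(/C=C/c1ccc(C(F)(F)F)cc1F)Cc1ccc(Nc2ncnc3cc(Cl)ccc23)cc1` keeps the 2-fluoro-4-(trifluoromethyl)phenyl group of compound 2 and differs elsewhere: a group of 11 heavy atoms (8 carbon, 2 nitrogen, 1 chlorine; one six-membered aromatic ring of carbon only, one six-membered aromatic ring with 2 hetero atoms) in place of a group of 11 heavy atoms (8 carbon, 2 nitrogen, 1 bromine; one six-membered aromatic ring of carbon only, one six-membered aromatic ring with 2 hetero atoms), on a nitrogen on an aromatic ring. The entering group is 7-chloroquinazolin-4-yl.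

Going by the values given here, no measured step touches this part of the structure. All three exchange only the phenyl group on the double-bonded chain carbon, and the widest of them is a 5.0-fold higher number from compound 1 to compound 3 (0.70 log units; beyond the scatter). These steps therefore give only a rough idea of how far the series moves, and they say nothing direct about the new change. With no evidence for a direction, no shift beyond the scatter is expected in this assay, so the expected result is no change at the digits printed from compound 2 to compound 4 (within the scatter). The estimated value for compound 4 is 40000 nM, with an expected range from 13000 nM to 100000 nM.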

Compound 4, concentration for 50% growth inhibition: > 100000 nM
Compound 4 gave a limit, no number; the forecaster's own chance of this, stated with the estimate: 20%; at least 2.5-fold (0.39 log units) between middle value and limit.
By their numbers in this assay, from the lowest: compounds 1 and 2 (each within the scatter of the next); then compound 3.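

In this assay, placing 7-chloroquinazolin-4-yl on the nitrogen on an aromatic ring, in place of the bromine-bearing group of compound 2, gives an at least 2.5-fold higher number from compound 2 to compound 4 (0.39 log units; beyond the scatter), the first step shown at this part of the structure. Compound 4 reads > 100000 nM, which is a limit of the assay and not a number. The step therefore shows that growth inhibition responds to this group as well as to the phenyl group on the double-bonded chain carbon, though its true size stays unknown: the limit of > 100000 nM in this assay, at which 1 of the 4 values shown sits.

The compounds shown do not tell whether the step follows the change of halogen or some other difference between the two groups; 7-bromoquinazolin-4-yl or plain quinazolin-4-yl on the same nitrogen would bear on that. On these data alone, it also stays open whether the same exchange would move compound 1 in the same direction.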